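The compounds below may be only part of what the source reports. "The series", "measured", "known", "first", "only" and "open" are said of these compounds alone.

Measured so far in a functional assay on Rec1 cells (Homo sapiens) for inhibition, read by MTT assay, with a stated time of 24 h; on this read-out lower numbers stand for stronger inhibition of growth and higher numbers for weaker inhibition of growth:
- compound 1 `Nc1nc(Nc2ccccc2)nc2c1CC(c1c(Cl)cccc1Cl)C(=O)N2`: > 100000 nM (a limit)
- compound 2 `Nc1nc(N)c2c(n1)NC(=O)C(c1c(Cl)cccc1Cl)C2`: > 100000 nM (a limit)

Compound 1 has no numerical value, only the limit > 100000 nM. Compound 2 likewise has only a limit, > 100000 nM. All the data so far therefore amount to the limit of > 100000 nM in this assay, at which 2 of the 2 values shown sit.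

Compound 3 `CN1C(=O)C(c2c(Cl)cccc2Cl)Cc2c(N)nc(Nc3ccccc3)nc21` differs from compound 1 by one change: methyl in place of hydrogen on an amide-type nitrogen in a ring. This is methyl in place of hydrogen on an amide-type nitrogen in a ring, two ring bonds from the ring atom that bears a 2,6-dichlorophenyl group.

Among the measured compounds shown here, the only measured step, a step that the two limits leave unreadable from compound 1 to compound 2, involves a different group and offers no size to carry over. No direction of change can be expected in this assay, and no readable shift beyond the scatter is anticipated. The expected step is a number no higher from compound 1 to compound 3 (the limit leaves the size open). Compound 3 is estimated at 100000 nM, with an expected range from 20000 nM to 200000 nM.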

Compound 3, concentration for 50% growth inhibition: 67200 nM
Compound 3: the middle estimate sits 1.5-fold (0.17 log units) above what was measured; the measured number falls inside the stated range.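

In this assay, methyl on the amide-type nitrogen in the ring yields the first number rather than a limit, with compound 3 at 67200 nM. Methyl in place of hydrogen at this nitrogen, two ring bonds from the ring atom that bears a 2,6-dichlorophenyl group, gives an at least 1.4-fold lower number from compound 1 to compound 3 (0.17 log units; that floor lies within the scatter). From the compounds shown here alone, the true size of this step stays open, and most of the values shown remain limits: the limit of > 100000 nM in this assay, at which 2 of the 3 values shown sit.

The compounds shown leave open whether a longer chain such as ethyl, or a chain ending in an amine or a carboxylic acid, on this nitrogen would move the number further. They also leave open whether methyl at this nitrogen would have any readable effect on compound 2, which carries hydrogen in place of phenyl.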